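Replacing 1,3-thiazol-2-yl with 1H-pyrrol-2-yl

The compounds below may be only part of what the source reports. "The series", "measured", "known", "first", "only" and "open" are said of these compounds alone.

- Compound 1 `OC[C@H]1O[C@@H](n2cc(F)c3c(-c4ccccc4)ncnc32)[C@H](O)[C@@H]1O`: > 10000 nM (a limit of the assay)
- Compound 2 `OC[C@H]1O[C@@H](n2cc(F)c3c(-c4cccs4)ncnc32)[C@H](O)[C@@H]1O`: 61 nM
- Compound 3 `OC[C@H]1O[C@@H](n2cc(F)c3c(-c4nccs4)ncnc32)[C@H](O)[C@@H]1O`: 900 nM

Among the actual numbers in a functional assay on A549 cells (Homo sapiens), read by sulforhodamine B assay, with a stated time of 5 days (on this read-out higher numbers stand for weaker inhibition of growth and lower numbers for stronger inhibition of growth), compound 3 stands highest at 900 nM. Compound 1 gives only a limit. Compound 4 `OC[C@H]1O[C@@H](n2cc(F)c3c(-c4ccc[nH]4)ncnc32)[C@H](O)[C@@H]1O` carries 1H-pyrrol-2-yl in place of 1,3-thiazol-2-yl on an aromatic carbon.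

For the measured compounds named here, three measured steps bear on this ring. Leaving phenyl gave an at least 160-fold lower number from compound 1 to compound 2 (2.21 log units; beyond the scatter) and an at least 11-fold lower number from compound 1 to compound 3 (1.04 log units; beyond the scatter), both large. Closest to this change, thiophen-2-yl to 1,3-thiazol-2-yl gave a 15-fold higher number from compound 2 to compound 3 (1.17 log units; beyond the scatter), also large. The entering ring has one hetero atom, like the thiophen-2-yl of compound 2 at 61 nM, so a clear move towards that lower number seems likely, though not all the way.

The expected change is a 5.0-fold lower number from compound 3 to compound 4 (0.70 log units; beyond the scatter). For compound 4, the estimated value is 180 nM, with an expected range of 35 nM to 1500 nM.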

Compound 4, concentration for 50% growth inhibition: 190 nM
Beside the measured number, compound 4's estimate is 1.1-fold (0.02 log units) below it; low and high end bracket the measured number.
By their numbers in this assay, from the lowest: compound 2; then compound 4; then compound 3. At a limit, above all of these: compound 1.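

A ring without sulfur also works at this position: 1H-pyrrol-2-yl in place of 1,3-thiazol-2-yl gives a 4.7-fold lower number from compound 3 to compound 4 (0.68 log units; beyond the scatter) but still trails thiophen-2-yl, with a 3.1-fold higher number from compound 2 to compound 4 (0.49 log units; beyond the scatter) in the same assay. Against phenyl, the new ring gives an at least 52-fold lower number from compound 1 to compound 4 (1.72 log units; beyond the scatter) and so joins the other two five-membered rings on the lower side. That step rests on a limit for compound 1 in this assay: the limit of > 10000 nM in this assay, at which 1 of the 4 values shown sits.

These compounds cannot separate the hydrogen-bond donor that enters from the sulfur that leaves. As far as these compounds go, how a furan-2-yl ring, or an amine on the 1H-pyrrol-2-yl ring, would read stays open.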